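The compounds below may be only part of what the source reports. "The series", "measured", "known", "first", "only" and "open" are said of these compounds alone.

Working notes on the series. Three compounds of the shared core have numbers in an ADME assay on U-937 cells (Homo sapiens) for inhibition, read by CellTiter-Glo, with a stated time of 72 h; a higher number here means a weaker inhibitor of growth, a lower number a stronger inhibitor of growth. Compound 1 `CCN1CCN(c2ccc(Nc3ncc4c(n3)N(C)C(=O)N(c3cc(NC(=O)c5cccc(C(F)(F)F)c5)ccc3C)C4)cc2)CC1` gives 839 nM, and compound 3 `CCN1CCN(c2ccc(Nc3ncc4c(n3)N(C)C(=O)N(c3cc(NC(=O)c5cccc(C(F)(F)F)c5)ccc3C)C4)cn2)CC1` gives 1410 nM; the two values lie within the usual scatter of each other, so no order between them is claimed. Compound 2 `Cc1ccc(Nc2ncc3c(n2)N(C)C(=O)N(c2cc(NC(=O)c4ccc(-n5cccc5)c(C(F)(F)F)c4)ccc2C)C3)cn1` stands apart: in this assay compound 2 gives only a limit, > 25000 nM, not a number. Among the measured compounds shown here, this is the limit of > 25000 nM in this assay, at which 1 of the 3 values shown sits, so compound 2 is the one compound of the three without a defined value, and only a floor for its growth inhibition concentration is known. Compound 2 also differs from compound 1 and compound 3 in more than one place, so the gap between them cannot be assigned to any single change.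

The step to be followed goes from compound 2 to compound 4 `Cc1ccc(Nc2ncc3c(n2)N(C)C(=O)N(c2cc(NC(=O)c4ccc(C)c(C(F)(F)F)c4)ccc2C)C3)cn1`, which is not yet measured in this assay. The change is methyl in place of 1H-pyrrol-1-yl on an aromatic carbon, and nothing else in the structure moves. For the measured compounds named here, no measured pair in the set isolates this change, so the expected step rests on the position of compound 2 at the limit alone. In this assay the step from compound 2 to compound 4 is expected to be an at least 2.0-fold lower number from compound 2 to compound 4 (0.31 log units; beyond the scatter), with a real chance that only a limit is returned again. The estimate for compound 4 in this assay is 12000 nM, in a range from 3000 nM to 40000 nM.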

Compound 4, concentration for 50% growth inhibition: 19400 nM
Compound 4: the middle estimate sits 1.6-fold (0.21 log units) below what was measured, within the range that was stated.
By their numbers in this assay, from the lowest: compounds 1 and 3 (each within the scatter of the next); then compound 4. At a limit, above all of these: compound 2.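

On an aromatic carbon ortho to a trifluoromethyl group, methyl in place of 1H-pyrrol-1-yl gives a compound with a defined number in this assay, so this position can carry a substituent that leaves growth inhibition within the measurable range. The step is known from one side only, as an at least 1.2-fold lower number from compound 2 to compound 4 (0.11 log units; that floor lies within the scatter), and that floor does not establish a real gain; its true size cannot be read, as compound 2 has a limit and not a number: the limit of > 25000 nM in this assay, at which 1 of the 4 values shown sits. Compound 4 differs from compound 1 and from compound 3 in more than one place, so the series still has no single-change comparison that links this position to those two compounds.

On these data alone, what a different group at this position would do, such as an amine, a carboxylic acid or a longer chain, remains open. Also open is whether the change from 1H-pyrrol-1-yl to methyl would have the same effect on a compound carrying the ethylpiperazine-bearing aniline of compound 1, as the shown compounds do not isolate that case.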